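Trimming the Methylsulfonyl from Compound 2

The source may hold more compounds than are shown below. What is called first, only, known or untested is meant among the compounds shown, and "the series" means these compounds.

Three analogues sharing one core have been measured in a functional assay on MCF7 cells (Homo sapiens) for antiproliferative activity, read by MTT assay, with a stated time of 72 h; a higher number here means a weaker inhibitor, a lower number a stronger inhibitor. Compound 1 `O=C(Nc1ccc(Cl)c(-c2nnc3c(Cl)cccn23)c1)c1ccc(C(F)(F)F)cc1F` gives 62800 nM. Compound 2 `CS(=O)(=O)c1ccc(C(=O)Nc2ccc(Cl)c(-c3nnc4c(Cl)cccn34)c2)cc1` gives 94200 nM, the higher of the two numbers, with compound 1 the nearest and that gap within the scatter. Compound 3 `CS(=O)(=O)c1ccc(C(=O)Nc2ccc(Cl)c(-c3nnc4c(Cl)cccn34)c2)c(Cl)c1` gives only a limit of the assay, > 100000 nM. The step of an at least 1.0-fold higher number from compound 2 to compound 3 (0.02 log units; that floor lies within the scatter), chloro in place of hydrogen on an aromatic carbon, therefore sits at its floor (the limit of > 100000 nM in this assay, at which 1 of the 3 values shown sits). Compound 4 `O=C(Nc1ccc(Cl)c(-c2nnc3c(Cl)cccn23)c1)c1ccccc1` differs from compound 2 by hydrogen in place of methylsulfonyl on an aromatic carbon. Within the data shown here, no measured step removes this group, so in this assay no step beyond the scatter is expected in either direction. Compound 4 is therefore estimated at 75000 nM, between 30000 nM and 150000 nM. The expected step is a 1.3-fold lower number from compound 2 to compound 4 (0.10 log units; within the scatter).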

Compound 4, half-maximal inhibitory concentration: > 100000 nM
Compound 4: no number, only a limit (the forecaster's own chance of this, stated with the estimate: 30%); middle value at least 1.3-fold (0.12 log units) from the limit.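

Hydrogen in place of methylsulfonyl gives an at least 1.0-fold higher number from compound 2 to compound 4 (0.02 log units; that floor lies within the scatter), so the change from 4-(methylsulfonyl)phenyl to phenyl brings no measurable gain in strength. In this assay compound 4 gives only a limit, > 100000 nM. The step therefore sits at its floor and its true size cannot be read, which now holds for both changes tested on this ring: the limit of > 100000 nM in this assay, at which 2 of the 4 values shown sit.

As far as these compounds go, whether another group at this place, such as an amine or a carboxylic acid, would give a number rather than a limit stays open. Compound 1 differs from compound 4 in more than one place, so it cannot settle this.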